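Ring-bearing carbamate in compound 4: an expected efficacy

The source may hold more compounds than are shown below. What is called first, only, known or untested is meant among the compounds shown, and "the series" means these compounds.

In a functional assay on isolated protein for inhibition of Glucose-dependent insulinotropic receptor (Rattus norvegicus), read by HTRF and cAMP accumulation (on this read-out higher numbers stand for larger maximal responses and lower numbers for smaller maximal responses), compound 1 `Cc1nc(S(C)(=O)=O)ccc1Oc1ncnc(OC2CCN(C(=O)OC(C)C)CC2)c1F` gives 77%, compound 2 `Cc1nc(S(C)(=O)=O)ccc1Oc1ncnc(OC2CCN(C(=O)OC(C)(C)C(F)(F)F)CC2)c1F` gives 79% and compound 3 `Cc1nc(S(C)(=O)=O)ccc1Oc1ncnc(OC2CCN(C(=O)O[C@@H](C)CF)CC2)c1F` gives 84%. Compound 3 shows the highest of the three numbers, yet a number 7 percentage points higher from compound 1 to compound 3 (within the scatter) and a number 5 percentage points higher from compound 2 to compound 3 (within the scatter) both stay inside the usual scatter, so none of the three can be called stronger than another. Compound 4 `Cc1nc(S(C)(=O)=O)ccc1Oc1ncnc(OC2CCN(C(=O)OC3(C(F)(F)F)CCC3)CC2)c1F` differs from compound 3 in one place: 1-(trifluoromethyl)cyclobutyl in place of 1-(fluoromethyl)ethyl on an oxygen next to a carbonyl group. The closest measured guide is a number 2 percentage points higher from compound 1 to compound 2 (within the scatter), where a trifluoromethyl likewise entered on a saturated chain carbon bound to an oxygen next to a carbonyl group. With every measured step inside the scatter, the expected step is a number 4 percentage points lower from compound 3 to compound 4 (within the scatter), nothing beyond the scatter. Compound 4 is therefore estimated at 80%, ranging from 70% to 90%.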

Compound 4, largest response reached (reported as efficacy), in percent of the reference or control that the assay uses: 82%
Compound 4: middle estimate off by 2 percentage points, on the low side; measured number inside the range.
By their numbers in this assay, from the lowest: compounds 1, 2, 4 and 3 (each within the scatter of the next).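

On the oxygen next to a carbonyl group, 1-(trifluoromethyl)cyclobutyl brings the first ring to this place, and the steps are a number 2 percentage points lower from compound 3 to compound 4 (within the scatter) and a number 3 percentage points higher from compound 2 to compound 4 (within the scatter) and a number 5 percentage points higher from compound 1 to compound 4 (within the scatter) as well, so the maximal response stays within the scatter whether this group is open-chain or ring-bearing. Nothing available explains this lack of a clear difference. Still open, from the compounds shown here alone, is whether a group of another kind on this oxygen, such as a phenyl ring or a chain ending in an amine, would move the response beyond the scatter.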